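A few compounds are considered here, and "the series" means these few. Any claim that something is new, unique, unknown or untested is made for them only; others in the source may bear on it.

Measured in a functional assay on SW480 cells (Homo sapiens) for cytotoxicity, read by MTT assay, with a stated time of 48 h; a higher number here means a weaker inhibitor, a lower number a stronger inhibitor:
- Compound 1 `Cc1cccc(Cn2cc(COc3ccc4c(=O)ccoc4c3)nn2)c1`: 11700 nM
- Compound 2 `O=c1ccoc2cc(OCc3cn(Cc4ccc(Cl)cc4)nn3)ccc12`: > 100000 nM (a limit)
- Compound 3 `O=c1ccoc2cc(OCc3cn(Cc4cccc(F)c4)nn3)ccc12`: > 100000 nM (a limit)

Compound 3 gives only a limit, > 100000 nM, and no number. Compound 4 `O=c1ccoc2cc(OCc3cn(Cc4cccc(Cl)c4)nn3)ccc12` differs from it in one place: chloro in place of fluoro on an aromatic carbon. Among the compounds with values here, no measured step makes this exact change. The nearest is an at least 8.5-fold higher number from compound 1 to compound 3 (0.93 log units; beyond the scatter), with fluoro in place of methyl on an aromatic carbon. Also relevant is an at least 8.5-fold higher number from compound 1 to compound 2 (0.93 log units; beyond the scatter), with 4-chlorophenyl in place of 3-methylphenyl. Finally, a step that the two limits leave unreadable from compound 2 to compound 3 gives no usable size. A modest drop in the number is therefore expected, with real doubt about whether compound 4 leaves the limit at all. The estimated change is an at least 2.0-fold lower number from compound 3 to compound 4 (0.30 log units; that floor lies within the scatter). For compound 4 the expected value is 50000 nM, within an estimated range of 12000 nM to 150000 nM.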

Compound 4, half-maximal inhibitory concentration: 12900 nM
The estimate for compound 4 lay 3.9-fold (0.59 log units) above the measured number; low and high end bracket the measured number.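

In this assay, the choice of group at this carbon of the benzyl ring matters: chloro in place of fluoro gives an at least 7.7-fold lower number from compound 3 to compound 4 (0.88 log units; beyond the scatter), and 3-chlorophenyl in place of 4-chlorophenyl gives an at least 7.7-fold lower number from compound 2 to compound 4 (0.88 log units; beyond the scatter). Chloro in place of methyl gives a 1.1-fold higher number from compound 1 to compound 4 (0.04 log units; within the scatter), so these two groups read alike here, while fluoro does not. The first two steps are only floors, because compound 2 and compound 3 each give a limit and not a number: the limit of > 100000 nM in this assay, at which 2 of the 4 values shown sit.

As far as these compounds go, what a bromo, a methoxy or an amine on this same carbon would give stays open.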